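Cyclopentyl for Benzyl: Expected Half-Life of Compound 3

The compounds below may be only part of what the source reports. "The series", "measured", "known", "first", "only" and "open" are said of these compounds alone.

Compound 1 `CCC(CC)C(/C=C1\OC(=O)NC1=O)c1ccc(-c2ccc3cccc(F)c3c2)[nH]c1=O`: in an ADME assay on microsomes from liver (Rattus norvegicus) for metabolic stability (on this read-out lower numbers stand for a shorter-lived compound and higher numbers for a longer-lived compound), compound 1 gives > 3 h, a limit of the assay rather than a number.
Compound 2 `O=C1NC(=O)/C(=C/C(Cc2ccccc2)c2ccc(-c3ccc4cccc(F)c4c3)[nH]c2=O)O1`: in this assay compound 2 gives 2.96 h.

Compound 2 thus holds the only number shown in this assay; the other value is a limit (the limit of > 3 h in this assay, at which 1 of the 2 values shown sits). Compound 3 `O=C1NC(=O)/C(=C/C(c2ccc(-c3ccc4cccc(F)c4c3)[nH]c2=O)C2CCCC2)O1` differs from compound 2 by cyclopentyl in place of benzyl on a saturated chain carbon bound to an aromatic carbon and a double-bonded chain carbon. Within the data shown here, the one measured step at this position, an at least 1.0-fold lower number from compound 1 to compound 2 (0.00 log units; that floor lies within the scatter), stayed within the scatter. For compound 3 a step of similar size is therefore expected, a 1.0-fold higher number from compound 2 to compound 3 (0.01 log units; within the scatter), in no clear direction. Compound 3 is estimated at 3 h, with a range from 1.5 h to 6 h.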

Compound 3, half-life: > 3 h
Compound 3 gave a limit, no number (the forecaster's own chance of this, stated with the estimate: 45%); the middle value sits exactly at the limit.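

Putting cyclopentyl in place of benzyl on this saturated chain carbon gives an at least 1.0-fold higher number from compound 2 to compound 3 (0.00 log units; that floor lies within the scatter), so a non-aromatic ring leaves no readable change in this assay. The step between compound 1 and compound 3 cannot be read, as both values are limits. How far these compounds differ stays hidden because the values crowd at the top of the range: the limit of > 3 h in this assay, at which 2 of the 3 values shown sit.

Open, going by these compounds, is whether an amine or a carboxylic acid on this carbon would give a shorter-lived compound. Also open, on these data alone, is whether a smaller group, such as methyl, would do so.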